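A few compounds are considered here, and "the series" means these few. Any claim that something is new, unique, unknown or untested is made for them only; others in the source may bear on it.

Series notes, antiproliferative read-out in a functional assay on Bel-7402 cells (Homo sapiens) for antiproliferative activity, read by MTT assay, with a stated time of 72 h; a higher number here means a weaker inhibitor, a lower number a stronger inhibitor:

- compound 1 `C=C1C(=O)O[C@H]2[C@H]1CC/C(COC(=O)Cn1cc(F)c(=O)[nH]c1=O)=C\CC[C@@]1(C)O[C@@H]21`: > 20000 nM (a limit of the assay)
- compound 2 `C=C1C(=O)O[C@H]2[C@H]1CC/C(Cn1cc(Cn3cc(F)c(=O)n(Cc4ccc(F)cc4)c3=O)nn1)=C\CC[C@@]1(C)O[C@@H]21`: 4910 nM
- compound 3 `C=C1C(=O)O[C@H]2[C@H]1CC/C(COC(=O)Cn1cc(F)c(=O)n(Cc3ccc(C(F)(F)F)cc3)c1=O)=C\CC[C@@]1(C)O[C@@H]21`: 2250 nM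
- compound 4 `C=C1C(=O)O[C@H]2[C@H]1CC/C(COC(=O)Cn1cc(F)c(=O)n(Cc3c(F)cccc3F)c1=O)=C\CC[C@@]1(C)O[C@@H]21`: not yet measured

Compound 3 has the lowest number among the measured values in this assay. Compound 2 comes next at 4910 nM, a gap beyond the scatter. Compound 1 stands at > 20000 nM, which is a limit of the assay.

The next change is 2,6-difluorophenyl in place of 4-(trifluoromethyl)phenyl on a saturated chain carbon bound to an aromatic nitrogen. Going by the values given here, the only measured step that bears on it is an at least 8.8-fold lower number from compound 1 to compound 3 (0.94 log units; beyond the scatter), where 4-(trifluoromethyl)benzyl replaces hydrogen on an aromatic nitrogen. Compound 4 keeps a benzyl group there, so most of the gain in that step is expected to remain. Among the compounds with values here, no measured step compares one benzyl substitution with another, so the expectation is only a small move toward a higher number, within the scatter. The expected change is a 1.6-fold higher number from compound 3 to compound 4 (0.19 log units; within the scatter). For compound 4 the estimated value is 3500 nM, with an expected range of 1200 nM to 10000 nM.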

Compound 4, half-maximal inhibitory concentration: 4500 nM
The estimate for compound 4 lay 1.3-fold (0.11 log units) below the measured number; low and high end bracket the measured number.
By their numbers in this assay, from the lowest: compounds 3, 4 and 2 (each within the scatter of the next, the first and the last beyond it). At a limit, above all of these: compound 1.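

In this assay, 2,6-difluorobenzyl in place of 4-(trifluoromethyl)benzyl gives a 2.0-fold higher number from compound 3 to compound 4 (0.30 log units; within the scatter), so this position does not separate the two substituted benzyl groups. The gain over the free ring nitrogen now appears with a second benzyl group, an at least 4.4-fold lower number from compound 1 to compound 4 (0.64 log units; beyond the scatter), and therefore does not rest on the trifluoromethyl group alone. The size of that step is only a floor, set by compound 1, whose value is a limit of the assay: the limit of > 20000 nM in this assay, at which 1 of the 4 values shown sits.

Going by these compounds, whether the aromatic ring is needed at all remains open, and a plain methyl group or a longer alkyl chain on that nitrogen would address it. On these data alone, how far the ring accepts other substituents, such as an amine or a carboxylic acid, is also open, and two fluorinated benzyl groups define no trend.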